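Amide nitrogen substituents on the shared core

A few compounds are considered here, and "the series" means these few. Any claim that something is new, unique, unknown or untested is made for them only; others in the source may bear on it.

The series keeps the core of compound 1 `COc1cc2c(cc1OC)C(CC(=O)N(C)C)CC2` and varies the group on the carbonyl carbon. In a functional assay on the whole organism (strain Wistar) for inhibition, with Rattus norvegicus as the target, read by paw edema, with stated times of 60 min and 4 h, at a dose of 100 mg/kg by the oral route (on this read-out higher numbers stand for more inhibition at the one dose given (going by the name of the read-out) and lower numbers for less inhibition), compound 1 gives 35.9%, the second highest of the three numbers. Compound 2 `CCCNC(=O)CC1CCc2cc(OC)c(OC)cc21` gives 26.6%, and compound 3 `COc1cc2c(cc1OC)C(CC(=O)NC(C)C)CC2` gives 39.1%; the step of a number 9.3 percentage points lower from compound 1 to compound 2 (within the scatter) and the step of a number 3.2 percentage points higher from compound 1 to compound 3 (within the scatter) both stay within the scatter, while the step of a number 12.5 percentage points higher from compound 2 to compound 3 (beyond the scatter) is the only one beyond it.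

Compound 4 `CCCCCNC(=O)CC1CCc2cc(OC)c(OC)cc21` is not yet measured. It differs from compound 1 by pentylamino in place of dimethylamino on a carbonyl carbon. Among the measured compounds shown here, the steps that bear on this change are those from compound 1 to compound 2 and to compound 3, both within the scatter, and the chain in compound 4 is closest in kind to the propyl chain of compound 2. No step beyond the scatter is therefore expected in this assay, with a lean toward the lower side given 26.6% for compound 2. Compound 4 is estimated at 29%, in the range 17% to 41%, which means an expected step of a number 6.9 percentage points lower from compound 1 to compound 4 (within the scatter).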

Compound 4, a percentage reported as inhibition, in the whole organism at one dose (the size of the read-out at that dose, not a potency): 40.6%
The estimate for compound 4 lay 11.6 percentage points below the measured number; the measured number falls inside the stated range.
By their numbers in this assay, from the lowest: compounds 2, 1, 3 and 4 (each within the scatter of the next, the first and the last beyond it).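

In this assay the longer chain on the amide nitrogen brings no loss of inhibition: the step of a number 14 percentage points higher from compound 2 to compound 4 (beyond the scatter) shows that the low number of the propyl compound does not carry on to pentyl. The steps of a number 4.7 percentage points higher from compound 1 to compound 4 (within the scatter) and a number 1.5 percentage points higher from compound 3 to compound 4 (within the scatter) stay within the scatter, so dimethylamino, isopropylamino and pentylamino cannot be told apart at this position, and compound 2 separates only from compound 3 and compound 4. Nothing on hand gives a reason for the gap between the propyl and pentyl chains.

On these data alone, whether the number holds with a longer chain such as octyl, or with a benzyl group or a terminal carboxylic acid on the amide nitrogen, stays open. With one dose only, the read-out gives no potency order for these amides.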